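Triazole thioethers on a shared phthalimide-bearing core: cytotoxicity notes

The source may hold more compounds than are shown below. What is called first, only, known or untested is meant among the compounds shown, and "the series" means these compounds.

Compound 1 `CCc1nnc(SCc2ccccc2)n1N1C(=O)c2ccccc2C1=O`, compound 2 `CCc1nnc(SCC(=O)c2ccc(Cl)cc2)n1N1C(=O)c2ccccc2C1=O` and compound 3 `CCCc1nnc(SCc2ccccc2)n1N1C(=O)c2ccccc2C1=O` have been tested in a functional assay on A549 cells (Homo sapiens) for cytotoxicity, read by MTT assay, with a stated time of 48 h; on this read-out lower numbers stand for stronger inhibition and higher numbers for weaker inhibition. In this assay compound 1 gives > 200000 nM, which is a limit of the assay and not a number. In this assay compound 2 gives > 200000 nM, again a limit. In this assay compound 3 gives > 200000 nM, also a limit. The change from compound 1 to compound 2 is (4-chlorophenyl)carbonyl in place of phenyl on a saturated chain carbon bound to a sulfur; it made a step that the two limits leave unreadable from compound 1 to compound 2. The two cores differ as follows: methyl in place of hydrogen on a saturated chain carbon, two bonds along the chain from an aromatic carbon, with a step that the two limits leave unreadable from compound 1 to compound 3. Compound 4 `CCCc1nnc(SCC(=O)c2ccc(Cl)cc2)n1N1C(=O)c2ccccc2C1=O` is not yet measured. It differs from compound 3 by (4-chlorophenyl)carbonyl in place of phenyl on a saturated chain carbon bound to a sulfur, the same change as from compound 1 to compound 2, at the same place. Among the measured compounds shown here, because of the limit of > 200000 nM in this assay, at which 3 of the 3 values shown sit, no measured compound has yet given a number, and the step from compound 3 to compound 4 is expected to be a number no higher from compound 3 to compound 4 (the limit leaves the size open), with the limit most likely reached again. Compound 4 is estimated at 200000 nM in this assay.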

Compound 4, half-maximal inhibitory concentration: > 200000 nM
Compound 4 ended at the assay's limit; the forecaster's own chance of this, stated with the estimate: 85%; the middle value sits exactly at the limit.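

No new step can be read from compound 3 or compound 2 to compound 4, as each value is a limit of the assay and not a number: the limit of > 200000 nM in this assay, at which 4 of the 4 values shown sit.

The compounds shown leave open whether any change on the shared core gives a number in this assay, and what size either change would have on such a compound.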